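Ester-to-amide change on the carbonyl carbon: outlook for compound 4

This account rests on a few compounds, and the source may have more. Where it says the series, first, only, none or still open, it means among the compounds named here.

Measured so far:
Compound 1 `CCN(CC)CCNC(=O)c1ccc(C(CC)(CC)c2ccc(OCCC(O)(CC)CC)c(C)c2)n1CC` gives 3350 nM in a functional assay on PC-3 cells (Homo sapiens) for antiproliferative activity, read by MTT assay, with a stated time of 48 h; on this read-out higher numbers stand for weaker inhibition and lower numbers for stronger inhibition.
Compound 2 `C#CCCOC(=O)c1ccc(C(CC)(CC)c2ccc(OCCC(O)(CC)CC)c(C)c2)n1CC` reaches only the assay limit > 50000 nM in this assay, so no number is known for it.
Compound 3 `CCOC(=O)C(CC(=O)OC)NC(=O)c1ccc(C(CC)(CC)c2ccc(OCCC(O)(CC)CC)c(C)c2)n1CC` gives 5840 nM in this assay.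

Compound 2 thus stands at the weak end of the three, at the limit (the limit of > 50000 nM in this assay, at which 1 of the 3 values shown sits), with no measured number of its own.

Compound 4 `CCn1c(C(=O)NC(C)CO)ccc1C(CC)(CC)c1ccc(OCCC(O)(CC)CC)c(C)c1` is not yet measured. It differs from compound 2 by (1-(hydroxymethyl)ethyl)amino in place of (but-3-yn-1-yl)oxy on a carbonyl carbon. The two measured steps that bear on this are the ester-to-amide changes on the same carbonyl carbon: an at least 14-fold higher number from compound 1 to compound 2 (1.17 log units; beyond the scatter) and an at least 8.5-fold lower number from compound 2 to compound 3 (0.93 log units; beyond the scatter). Both show that the ester of compound 2 sits far below the amides, and the two amides lie within the scatter of each other, as a 1.7-fold higher number from compound 1 to compound 3 (0.24 log units; within the scatter) shows. The third amide is therefore expected to fall into the same region as compounds 1 and 3.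

For compound 4 the expected step is an at least 10-fold lower number from compound 2 to compound 4 (1.00 log units; beyond the scatter), a clear move to a lower number. The estimate for compound 4 in this assay is 5000 nM, between 2000 nM and 15000 nM.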

Compound 4, half-maximal inhibitory concentration: 7870 nM
Compound 4: middle estimate off by 1.6-fold (0.20 log units), on the low side; the measured number falls inside the stated range.
By their numbers in this assay, from the lowest: compounds 1, 3 and 4 (each within the scatter of the next, the first and the last beyond it). At a limit, above all of these: compound 2.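

In this assay, the ester-to-amide change on the carbonyl carbon now holds with a leaving and an entering group of the same size, 5 heavy atoms each: the result is an at least 6.3-fold lower number from compound 2 to compound 4 (0.80 log units; beyond the scatter), so a larger group on this carbon is not needed for a measurable number. The start of that step is a limit and not a number: the limit of > 50000 nM in this assay, at which 1 of the 4 values shown sits.

On the amide-type nitrogen, the amides no longer form a single level: 1-(hydroxymethyl)ethyl in place of 2-(diethylamino)ethyl gives a 2.3-fold higher number from compound 1 to compound 4 (0.37 log units; beyond the scatter), a modest step, while the other comparison gives a 1.3-fold higher number from compound 3 to compound 4 (0.13 log units; within the scatter), which leaves compound 3 within the scatter of both ends of the set.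

With one ester shown, it remains open whether the loss belongs to esters on this carbonyl carbon in general or to the (but-3-yn-1-yl)oxy group alone; a plain ethyl ester or a carboxylic acid at this place would separate the two. From the compounds shown here alone, it is also open how the amide-type nitrogen responds to a ring-bearing group such as a benzyl, or to a primary amide with no chain on the nitrogen.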